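Adding a Methoxy to Compound 3

This account rests on a few compounds, and the source may have more. Where it says the series, first, only, none or still open, it means among the compounds named here.

In a functional assay on MOLT-3 cells (Homo sapiens) for antiproliferative activity (a higher number here means a weaker inhibitor, a lower number a stronger inhibitor), compound 1 `CCCNC(=O)c1cccc(NC(=O)C(C)Br)c1` gives 8940 nM. Compound 2 `CCCCNC(=O)c1cccc(NC(=O)C(C)Br)c1` reads > 10000 nM, which is a limit of the assay and not a number. Compound 3 `COc1cc(NC(=O)c2cccc(NC(=O)C(C)Br)c2)cc(OC)c1OC` gives 670 nM, the lowest number of the three and beyond the scatter from compound 1.

Compound 4 `COc1ccc(C(=O)Nc2cc(OC)c(OC)c(OC)c2)cc1NC(=O)C(C)Br` departs from compound 3 by one change, a methoxy in place of hydrogen on an aromatic carbon. Among the compounds with values here, only one measured step exists, an at least 1.1-fold higher number from compound 1 to compound 2 (0.04 log units; that floor lies within the scatter). It concerns a methyl on a saturated chain, and its floor lies within the scatter. Within the data shown here, no measured step tests a methoxy on an aromatic carbon, so the value of compound 3 at 670 nM remains the only anchor, and no shift beyond the scatter is expected in either direction in this assay. The estimated change is a 1.3-fold lower number from compound 3 to compound 4 (0.13 log units; within the scatter), a small one. For compound 4 the estimated value is 500 nM, with an expected range of 120 nM to 2000 nM.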

Compound 4, half-maximal inhibitory concentration: 4240 nM
Beside the measured number, compound 4's estimate is 8.5-fold (0.93 log units) below it; the measured number lies above the stated range.
By their numbers in this assay, from the lowest: compound 3; then compound 4; then compound 1. At a limit, above all of these: compound 2.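

In this assay, methoxy in place of hydrogen on an aromatic carbon, ortho to a ((1-bromoethyl)carbonyl)amino group and para to a large group, gives a 6.3-fold higher number from compound 3 to compound 4 (0.80 log units; beyond the scatter). Within the data shown here, the only earlier step concerned a saturated chain and stayed within the scatter at its floor, whereas this one shows that the number responds to a change at this aromatic carbon. It shows this for methoxy at this one position only, so it is a single observation and not a rule for substituents on this carbon.

On these data alone, whether a smaller group such as fluorine, or a hydroxyl or an amine, on the same carbon would also raise the number remains open. Nothing measured here bears on why methoxy at this position raises the number.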